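Shifting the Fluorine on the Fluorobenzyl Arm

The source may hold more compounds than are shown below. What is called first, only, known or untested is meant among the compounds shown, and "the series" means these compounds.

Measured compounds:
compound 1 `O=C1/C(=C/c2ccccc2F)CN(C(=S)SCc2cn(Cc3ccc(F)cc3)nn2)C/C1=C\c1ccccc1F` — 56900 nM
compound 2 `Cc1ccc(/C=C2\CN(C(=S)SCc3cn(Cc4ccccc4Cl)nn3)C/C(=C\c3ccc(C)cc3)C2=O)cc1` — > 100000 nM
compound 3 `Cc1ccc(/C=C2\CN(C(=S)SCc3cn(Cc4cccc(Cl)c4)nn3)C/C(=C\c3ccc(C)cc3)C2=O)cc1` — > 100000 nM

All three were tested in a functional assay on MCF7 cells (Homo sapiens) for cytotoxicity, read by MTT assay, with a stated time of 24 h; on this read-out higher numbers stand for weaker inhibition and lower numbers for stronger inhibition. For the measured compounds named here, compound 1 stands as the only plain number among the three results. For compound 2 the reported value is a limit of the assay, not a number. For compound 3 the reported value is likewise a limit. Two results thus sit at the limit of > 100000 nM in this assay, at which 2 of the 3 values shown sit. Going by the values given here, the one measured step, a step that the two limits leave unreadable from compound 2 to compound 3, has no readable size. Compound 4 `O=C1/C(=C/c2ccccc2F)CN(C(=S)SCc2cn(Cc3ccccc3F)nn2)C/C1=C\c1ccccc1F` has not been measured; it differs from compound 1 by 2-fluorophenyl in place of 4-fluorophenyl on a saturated chain carbon bound to an aromatic nitrogen. Among the compounds with values here, no measured step moves a fluorine on this arm, so no change beyond the scatter is expected, and the expected step is a 1.1-fold higher number from compound 1 to compound 4 (0.02 log units; within the scatter). Compound 4 is estimated at 60000 nM, in the range 25000 nM to 150000 nM.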

Compound 4, half-maximal inhibitory concentration: 51600 nM
Compound 4: middle estimate off by 1.2-fold (0.07 log units), on the high side; low and high end bracket the measured number.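

Exchanging 4-fluorobenzyl for 2-fluorobenzyl in this assay gives a 1.1-fold lower number from compound 1 to compound 4 (0.04 log units; within the scatter) and so provides the first readable size for moving a halogen around this arm. On the shared core of compound 1, the place of the fluorine on this ring makes no difference beyond the scatter. The chlorine shift from compound 2 to compound 3 cannot be read, since each of those two results is a limit of the assay and not a number: the limit of > 100000 nM in this assay, at which 2 of the 4 values shown sit.

From the compounds shown here alone, whether an amine or a carboxylic acid on this benzyl ring would shift the number remains open.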